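This account rests on a few compounds, and the source may have more. Where it says the series, first, only, none or still open, it means among the compounds named here.

Among the compounds with values here, in a functional assay on U-251 cells (Homo sapiens) for antiproliferative activity, read by MTT assay, with a stated time of 24 h (on this read-out higher numbers stand for weaker inhibition and lower numbers for stronger inhibition), compound 2 `COc1cc(OC)c(-c2coc3cc(OCc4ccc(Cl)cc4)ccc3c2=O)cc1OC` gives 470 nM, the only actual number so far. Compound 1 `COc1cc(OC)c(-c2coc3cc(OCc4ccccc4C(F)(F)F)ccc3c2=O)cc1OC` stands at > 10000 nM, which is a limit of the assay. Compound 3 `COc1cc(OC)c(-c2coc3cc(OCc4ccc(C(F)(F)F)cc4)ccc3c2=O)cc1OC` carries one change from compound 2: trifluoromethyl in place of chloro on an aromatic carbon, para to a large group. Within the data shown here, the only measured step bearing on this is large, an at least 21-fold lower number from compound 1 to compound 2 (1.32 log units; beyond the scatter), but it gives no direct size for this swap. A modest rise in this assay is therefore expected, possibly not beyond the scatter. The expected step is a 1.7-fold higher number from compound 2 to compound 3 (0.23 log units; within the scatter). Compound 3 is estimated at 800 nM, within 200 nM to 4000 nM.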

Compound 3, half-maximal inhibitory concentration: 3750 nM
The estimate for compound 3 lay 4.7-fold (0.67 log units) below the measured number, and the stated range covers the measured number.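

Trifluoromethyl in place of chloro on the aromatic carbon para to a large group gives an 8.0-fold higher number from compound 2 to compound 3 (0.90 log units; beyond the scatter) in this assay, so the read-out responds to the group at this carbon, with chloro the better of the two. The 4-(trifluoromethyl)phenyl in place of 2-(trifluoromethyl)phenyl gives an at least 2.6-fold lower number from compound 1 to compound 3 (0.42 log units; beyond the scatter), so where trifluoromethyl sits also counts. That step is only a bound, since the value of compound 1 is a limit: the limit of > 10000 nM in this assay, at which 1 of the 3 values shown sits.

Going by these compounds, whether chloro itself is favoured or trifluoromethyl is simply disfavoured remains open. Fluoro, methoxy or nitrile at the same carbon, or plain benzyl, would help separate the two.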